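This account rests on a few compounds, and the source may have more. Where it says the series, first, only, none or still open, it means among the compounds named here.

Measured so far in a functional assay on DU-145 cells (Homo sapiens) for antiproliferative activity, read by propidium iodide staining, with a stated time of 96 h; on this read-out lower numbers stand for stronger inhibition and higher numbers for weaker inhibition:
compound 1, `CC(O)(CSc1ccccc1C(F)(F)F)C(=O)Nc1ccc(S(F)(F)(F)(F)F)cc1`, gives 15800 nM
compound 2, `CC(O)(CSc1ccccc1OC(F)(F)F)C(=O)Nc1ccc(S(F)(F)(F)(F)F)cc1`, gives 29000 nM
compound 3, `CC(O)(CSc1ccc(C(F)(F)F)cc1)C(=O)Nc1cccc(S(F)(F)(F)(F)F)c1`, gives 27200 nM

Compound 2 differs from compound 1 by trifluoromethoxy in place of trifluoromethyl on an aromatic carbon, and that step was a 1.8-fold higher number from compound 1 to compound 2 (0.26 log units; within the scatter). Compound 3 shares its atoms with compound 1, joined differently; the difference between the two cores is not broken down here. Compound 4, `CC(O)(CSc1ccc(OC(F)(F)F)cc1)C(=O)Nc1cccc(S(F)(F)(F)(F)F)c1`, is not yet measured and differs from compound 3 by trifluoromethoxy in place of trifluoromethyl on an aromatic carbon. The two changes are of the same kind rather than the same, since in the first pair the place is ortho to a large group and in the second it is para to a large group. Alongside the earlier step, the expected step for compound 4 is a 1.5-fold higher number from compound 3 to compound 4 (0.17 log units; within the scatter), resting on a 1.8-fold higher number from compound 1 to compound 2 (0.26 log units; within the scatter) seen between compound 1 and compound 2. The estimate for compound 4 in this assay is 40000 nM, between 18000 nM and 90000 nM.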

Compound 4, half-maximal inhibitory concentration: 24700 nM
Compound 4: the middle estimate sits 1.6-fold (0.21 log units) above what was measured, within the range that was stated.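

In this assay, trifluoromethoxy in place of trifluoromethyl gave a 1.1-fold lower number from compound 3 to compound 4 (0.04 log units; within the scatter), so on this core too the change makes no step beyond the scatter. Set beside the earlier pair, the two steps cannot be told apart: the same change on two cores in this assay, a 1.8-fold higher number (0.26 log units; within the scatter) from compound 1 to compound 2 and a 1.1-fold lower number (0.04 log units; within the scatter) from compound 3 to compound 4, 2.0-fold (0.31 log units) apart, within the scatter of two such steps. This shows that, for these two pairs, the change carried from one core to the other without a readable difference, but it does not show that the step is the same on every core, and the place of the change also differs between the pairs, so core and place cannot be separated.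

The compounds shown leave open how other groups at this place, such as a nitrile, an amine or a carboxylic acid, would compare. They also leave open whether any such group would give a step beyond the scatter.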